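The source may report more compounds than this note shows. Statements on the series, on what has been measured and on what is new or still open speak of the compounds shown alone.

Measured so far in a functional assay on HT-29 cells (Homo sapiens) for cytotoxicity, read by MTT assay, with a stated time of 6 days; on this read-out higher numbers stand for an effect only at larger amounts of compound and lower numbers for an effect already at smaller amounts:

- Compound 1 `COC(=O)c1c(-c2ccc([N+](=O)[O-])cc2)oc2ccccc2c1=O`: in this assay compound 1 gives > 25 ug/mL, which is a limit of the assay and not a number.
- Compound 2 `COC(=O)c1c(-c2ccc(N)cc2)oc2ccccc2c1=O`: in this assay compound 2 gives > 25 ug/mL, again only a limit.
- Compound 3 `O=c1cc(-c2ccc([N+](=O)[O-])cc2)oc2ccc(O)cc12`: in this assay compound 3 gives > 25 ug/mL, also a limit.

Compound 1 and compound 2 share one core and differ by amino in place of nitro on an aromatic carbon. The step that the two limits leave unreadable from compound 1 to compound 2 is therefore not readable in size, because both values sit at the limit of > 25 ug/mL in this assay, at which 3 of the 3 values shown sit. Compound 3 carries another core; how it differs from compound 1 is not broken down here.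

Compound 4 `Nc1ccc(-c2cc(=O)c3cc(O)ccc3o2)cc1` is not yet measured. It differs from compound 3 by amino in place of nitro on an aromatic carbon. Going by the values given here, the change is the same as the one between compound 1 and compound 2, with the same surroundings, so it is the same change, made in both pairs.

The expected step is a step that the limit leaves unreadable from compound 3 to compound 4, close to nothing, which rests on the unreadable step that the two limits leave unreadable from compound 1 to compound 2. For compound 3 the value is a limit, > 25 ug/mL, so any effect of the change cannot be seen from that side either. Compound 4 is expected to give 40 ug/mL. For compound 4 the expected range runs from 12 ug/mL to 120 ug/mL, and most likely this assay will again report only a limit. Among the compounds with values here, no pattern beyond these pairs is claimed.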

Compound 4, concentration for half-maximal effect: 2.65 ug/mL
Estimate against measurement, compound 4: 15-fold (1.18 log units) above, outside the stated range (below it).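

Amino in place of nitro on an aromatic carbon gives, in this assay, an at least 9.4-fold lower number from compound 3 to compound 4 (0.97 log units; beyond the scatter), a step beyond the scatter whose full size remains unread. On the core of compound 1 the same change leaves compound 2 still at a limit, so that step cannot be read, because neither of the two compounds on this core has a numerical value: the limit of > 25 ug/mL in this assay, at which 3 of the 4 values shown sit. The change therefore yields a measured value on one core and only a limit on the other, which shows that the outcome did not repeat across these two cores, but it does not show that the two steps differ in size, and this single readable pair supports no general rule for the series.

Going by these compounds, it remains open whether the result depends on amino itself, or whether a dimethylamino group, an acetamide or a carboxylic acid at the same place would give a similar value in this assay. Also open is which feature separates the core of compound 1 from the core of compound 3, since the compounds shown do not change those differences one at a time.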